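The compounds below may be only part of what the source reports. "The series", "measured", "known", "first", "only" and "open" are said of these compounds alone.

Compound 2 `CN1CCCN(CCn2ccc3ccc(C(F)(F)F)cc32)CC1` gives 23 nM in an assay on HEK293 cells for binding affinity to 5-hydroxytryptamine receptor 7 (Homo sapiens), read by radioligand binding (a higher number here means a weaker inhibitor, a lower number a stronger inhibitor), the lowest of the two numbers shown, with compound 1 `CN1CCCN(CCn2ccc3ccc(Cl)cc32)CC1` close by at 34 nM. Among the measured compounds shown here, the only measured step, a 1.5-fold lower number from compound 1 to compound 2 (0.17 log units; within the scatter), lies within the scatter. Compound 3 `C=Cc1ccc2ccn(CCN3CCCN(C)CC3)c2c1` differs from compound 2 by vinyl in place of trifluoromethyl on an aromatic carbon. For the measured compounds named here, no measured step exchanges a trifluoromethyl for a vinyl, and the one comparison on this aromatic carbon stayed within the scatter. The expected step is therefore a 1.5-fold higher number from compound 2 to compound 3 (0.18 log units; within the scatter), not beyond the scatter. Compound 3 is expected to give 35 nM in this assay, with a range from 12 nM to 100 nM.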

Compound 3, inhibition constant: 109 nM
Estimate against measurement, compound 3: 3.1-fold (0.49 log units) below; the measured number lies above the stated range.
By their numbers in this assay, from the lowest: compounds 2 and 1 (each within the scatter of the next); then compound 3.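

Chloro and trifluoromethyl on this aromatic carbon could not be told apart, so the earlier compounds gave no sign that the group there matters. Vinyl stands apart from both, with a 4.7-fold higher number from compound 2 to compound 3 (0.68 log units; beyond the scatter) and a 3.2-fold higher number from compound 1 to compound 3 (0.51 log units; beyond the scatter) in binding to this receptor. The position therefore responds to at least one change of group, and the swap to vinyl costs affinity against either earlier group.

On these data alone, whether a methoxy, a nitrile or an ethyl group here would stay with chloro and trifluoromethyl or fall with vinyl remains open. Nothing at hand accounts for the vinyl result.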